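Moving a Hydroxyl Group: From Compound 3 to Compound 4

This account rests on a few compounds, and the source may have more. Where it says the series, first, only, none or still open, it means among the compounds named here.

Measured in an assay on isolated protein for inhibition of DNA topoisomerase 1 (Homo sapiens), with a stated time of 30 min, tested at 100 uM; a higher number here means more inhibition at the concentration tested (going by the name of the read-out), a lower number less inhibition:
Compound 1 `Oc1ccc(-c2cc(-c3ccc(O)cc3)nc(-c3ccc(O)cc3)c2)cc1`: 3.8%
Compound 2 `Oc1ccc(-c2cc(-c3cccc(O)c3)nc(-c3cccc(O)c3)c2)cc1`: 0%
Compound 3 `Oc1ccc(-c2cc(-c3cccc(O)c3)cc(-c3cccc(O)c3)n2)cc1`: 0%

Compound 3 stands level with compound 2 at the digits shown, and the number for compound 1 differs from both only within the usual scatter, so none of the three shows any clear inhibition. Compound 4 `Oc1ccc(-c2cc(-c3ccc(O)cc3)nc(-c3cccc(O)c3)c2)cc1` is not yet measured. It differs from compound 3 in one place: 4-hydroxyphenyl in place of 3-hydroxyphenyl on an aromatic carbon. Compounds 1, 2 and 3 show that neither arrangement of the three hydroxyphenyl groups seen so far gave inhibition, so the change is expected to bring no step beyond the scatter in this assay. Compound 4 is expected to give 2%, between 0% and 10%. This estimate means an expected step of a number 2 percentage points higher from compound 3 to compound 4 (within the scatter).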

Compound 4, a percentage reported as inhibition, at one concentration (the size of the read-out at that concentration, not a potency): 0%
Estimate against measurement, compound 4: 2 percentage points above; the range from low to high includes it.
By their numbers in this assay, from the lowest: compounds 2, 3, 4 and 1 (each within the scatter of the next).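

Placing 4-hydroxyphenyl instead of 3-hydroxyphenyl opposite the ring nitrogen brings no change at the digits printed from compound 3 to compound 4 (within the scatter) in this assay. The same exchange on another aromatic carbon brings no change at the digits printed from compound 2 to compound 4 (within the scatter) and the reverse exchange brings a number 3.8 percentage points lower from compound 1 to compound 4 (within the scatter) so, across these four compounds, moving a hydroxyl group around the outer rings produces no step beyond the scatter. Nothing available explains this flat result. Still open, going by these compounds, is whether an amine, a carboxylic acid or a methoxy group in place of a hydroxyl group would give clear inhibition in this assay.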